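Free fraction after exchanging the group on the carbonyl

The source may hold more compounds than are shown below. What is called first, only, known or untested is meant among the compounds shown, and "the series" means these compounds.

Measured in an ADME assay on a cell-free system (plasma, Mus musculus) for protein binding, read by LC-MS, with a stated time of 4 h, tested at 5 uM; on this read-out lower numbers stand for a smaller free fraction and higher numbers for a larger free fraction:
- compound 1 `O=C(NCc1ccc(S(=O)(=O)c2cccc(C(F)(F)F)c2)cc1)c1cc2cnccc2[nH]1`: 0.007
- compound 2 `O=C(NCc1ccc(S(=O)(=O)c2cc(F)cc(F)c2)cc1)c1cc2cnccc2[nH]1`: 0.028

Of these two, compound 2 has the higher number, at 0.028. Compound 3 `O=C(NCc1ccc(S(=O)(=O)c2cc(F)cc(F)c2)cc1)c1cnc2nccn2c1` differs from compound 2 by a group of 9 heavy atoms (6 carbon, 3 nitrogen; one five-membered aromatic ring with 2 hetero atoms, one six-membered aromatic ring with 2 hetero atoms) in place of a group of 9 heavy atoms (7 carbon, 2 nitrogen; one five-membered aromatic ring with 1 hetero atom, one six-membered aromatic ring with 1 hetero atom), on a carbonyl carbon. The entering group has more nitrogen and no hydrogen-bond donor.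

Within the data shown here, the only measured step is a 4.0-fold higher number from compound 1 to compound 2 (0.60 log units; beyond the scatter). That change lies on a sulfonyl sulfur, not on a carbonyl carbon, so it is only a loose guide to size. Among the measured compounds shown here, no measured step covers the present exchange, and the data give no direct evidence of its direction. A modest rise in this assay, similar in size to that step, is nevertheless expected, and the estimated change is a 2.9-fold higher number from compound 2 to compound 3 (0.46 log units; beyond the scatter).

For compound 3 the expected value is 0.08, with an estimated range from 0.03 to 0.2.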

Compound 3, unbound fraction: 0.133
Compound 3: the middle estimate sits 1.7-fold (0.22 log units) below what was measured; the range from low to high includes it.
By their numbers in this assay, from the lowest: compound 1; then compound 2; then compound 3.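

In this assay, the exchange on the carbonyl carbon gives a 4.8-fold higher number from compound 2 to compound 3 (0.68 log units; beyond the scatter) with the sulfonyl side held fixed, so this position also moves the free fraction, as the sulfonyl sulfur did with a 4.0-fold higher number from compound 1 to compound 2 (0.60 log units; beyond the scatter) in the earlier pair. The entering group brings 0 hydrogen-bond donors and 3 hydrogen-bond acceptors in place of 1 hydrogen-bond donor and 1 hydrogen-bond acceptor, and in this single pair the two differences cannot be told apart. No measurement shown bears on the reason for the rise.

From the compounds shown here alone, whether the same exchange on the carbonyl carbon carries over to the 3-(trifluoromethyl)phenyl partner remains open. So does the reading for an amine or a carboxylic acid on the group at the carbonyl carbon.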